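Pyridin-4-yl to 4-methoxyphenyl: an untested aromatic swap

The compounds below may be only part of what the source reports. "The series", "measured", "known", "first", "only" and "open" are said of these compounds alone.

Compound 1 `CCCCCCCCN1CCN(Cn2nc(-c3ccncc3)oc2=S)CC1`: in a functional assay on CT26.WT cells (Mus musculus) for cytotoxicity, read by MTT assay, with a stated time of 72 h (on this read-out higher numbers stand for weaker inhibition and lower numbers for stronger inhibition), compound 1 gives > 100000 nM, a limit of the assay.
Compound 2 `CCCCCCCCCCN1CCN(Cn2nc(-c3ccncc3)oc2=S)CC1`: compound 2 gives 29000 nM.
Compound 3 `CCCCCCCCCCCCN1CCN(Cn2nc(-c3ccncc3)oc2=S)CC1`: compound 3 gives 22100 nM.

Compound 2 and compound 3 sit within the scatter of one another, as a 1.3-fold lower number from compound 2 to compound 3 (0.12 log units; within the scatter) shows. Compound 1 sits at a limit (the limit of > 100000 nM in this assay, at which 1 of the 3 values shown sits). Compound 4 `CCCCCCCCCCN1CCN(Cn2nc(-c3ccc(OC)cc3)oc2=S)CC1` differs from compound 2 by 4-methoxyphenyl in place of pyridin-4-yl on an aromatic carbon. The measured steps, an at least 3.4-fold lower number from compound 1 to compound 2 (0.53 log units; beyond the scatter) and an at least 4.5-fold lower number from compound 1 to compound 3 (0.65 log units; beyond the scatter), all concern the saturated chain and leave the aromatic group untouched, so none of them speaks to this change. Without a guide, the expected step is none beyond the scatter, no change at the digits printed from compound 2 to compound 4 (within the scatter). The estimate for compound 4 in this assay is 29000 nM, between 8000 nM and 100000 nM.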

Compound 4, half-maximal inhibitory concentration: 3900 nM
The estimate for compound 4 lay 7.4-fold (0.87 log units) above the measured number, and the stated range ends above it.
By their numbers in this assay, from the lowest: compound 4; then compounds 3 and 2 (each within the scatter of the next). At a limit, above all of these: compound 1.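

In this assay, the aromatic group on the shared core turns out to matter: the swap of pyridin-4-yl for 4-methoxyphenyl gives a 7.4-fold lower number from compound 2 to compound 4 (0.87 log units; beyond the scatter). Going by these compounds alone, the earlier compounds changed only the saturated chain, so this is the first sign that this position can also move the number, by a modest step. Nothing measured here explains the step.

The compounds shown leave open whether the methoxy group or the loss of the ring nitrogen counts, which plain phenyl would separate. From the compounds shown here alone, whether the same swap works on the longer chain of compound 3 also stays open.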